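This account rests on a few compounds, and the source may have more. Where it says the series, first, only, none or still open, it means among the compounds named here.

For the measured compounds named here, compound 3 `CCC/N=C(\S)OC[C@H]1OC(n2cnc3c(NC4CCOC4)ncnc32)[C@H](O)[C@@H]1O` gives 50 nM in an assay on DDT1 cells (Cricetulus griseus) for binding affinity to adenosine receptor A1 (Homo sapiens), read by radioligand binding (a lower number here means a stronger inhibitor, a higher number a weaker inhibitor), the lowest of the three numbers measured so far, though it sits within the scatter of both neighbours. Compound 2 `CC/N=C(\S)OC[C@H]1OC(n2cnc3c(NC4CCOC4)nc(Cl)nc32)[C@H](O)[C@@H]1O` gives 55 nM in this assay, and compound 1 `CNC(=O)OC[C@H]1OC(n2cnc3c(NC4CCOC4)nc(Cl)nc32)[C@H](O)[C@@H]1O` gives 96 nM. Compound 4 `O=C(NC1CC1)OC[C@H]1OC(n2cnc3c(NC4CCOC4)ncnc32)[C@H](O)[C@@H]1O` has not yet been measured in this assay.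

The change from compound 3 to compound 4 is a group of 6 heavy atoms (4 carbon, 1 nitrogen, 1 oxygen; one three-membered non-aromatic ring of carbon only) in place of a group of 6 heavy atoms (4 carbon, 1 nitrogen, 1 sulfur; no ring), on an oxygen on a saturated carbon. Going by the values given here, only one measured step touches the same position: a 1.7-fold lower number from compound 1 to compound 2 (0.24 log units; within the scatter), which swapped a carbamate group for a thioimidate group on that oxygen and moved the number less than the scatter allows. Compound 4 goes the other way, back to a carbamate, now carrying a cyclopropyl group. Compounds 2 and 3 differ in two places at once and their values lie close together, so neither supports a large movement from this change.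

On this basis the step expected in this assay for compound 4 is a 1.6-fold higher number from compound 3 to compound 4 (0.20 log units; within the scatter), a number somewhat higher than that of compound 3 but not beyond the scatter. Compound 4 is therefore estimated at 80 nM, with a range from 35 nM to 180 nM.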

Compound 4, inhibition constant: 209 nM
Compound 4: the middle estimate sits 2.6-fold (0.42 log units) below what was measured; the measured number lies above the stated range.
By their numbers in this assay, from the lowest: compounds 3, 2 and 1 (each within the scatter of the next); then compound 4.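

In this assay, for the compounds shown here, the step of a 4.2-fold higher number from compound 3 to compound 4 (0.62 log units; beyond the scatter) is the first at this position to pass the scatter, while the earlier step on the same oxygen a 1.7-fold lower number from compound 1 to compound 2 (0.24 log units; within the scatter) stayed within it. The exchange of the open-chain sulfur-bearing group for cyclopropylcarbamoyl on an oxygen on a saturated carbon is therefore not neutral in this pair, although the group that leaves and the group that enters match in heavy-atom, donor, acceptor and double-bond counts. Nothing available here bears on why the number rises.

The single step replaces the sulfur with an oxygen and the open chain with a cyclopropyl ring at once, so the compounds shown leave open which of the two changes carries the rise, and a propyl carbamate or a cyclopropyl thioimidate on the same oxygen would separate them. They also leave open whether the same step would be seen on the chlorine-bearing core of compound 1 and compound 2, and how a longer chain or an amine on the carbamate nitrogen would read.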